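Trimming a Methyl from a Dimethylphenyl Group

This account rests on a few compounds, and the source may have more. Where it says the series, first, only, none or still open, it means among the compounds named here.

Compound 1, `COc1cc(-c2cc3nccc(-c4cc(OC)c(OC)c(OC)c4)n3n2)cc(OC)c1OC`, gives > 10000 nM in a functional assay on A549 cells (Homo sapiens) for inhibition, read by CCK-8 assay, with a stated time of 48 h (on this read-out lower numbers stand for stronger inhibition and higher numbers for weaker inhibition), which is a limit of the assay rather than a number.
Compound 2, `Cn1ccc2cc(-c3cc4nccc(-c5ccc(F)cc5)n4n3)ccc21`, gives 3520 nM in this assay.
Compound 3, `COc1cc(-c2ccnc3cc(-c4ccc(C)c(C)c4)nn23)cc(OC)c1OC`, gives 272 nM in this assay.

Among the two numbers that were obtained, compound 3 has the lowest, so it is the stronger inhibitor of the pair; compound 2 sits at a higher number, and that gap lies beyond the usual scatter. Compound 1 reached only the limit.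

Compound 4, `COc1cc(-c2ccnc3cc(-c4cccc(C)c4)nn23)cc(OC)c1OC`, has not yet been measured in this assay. It differs from compound 3 in one place: hydrogen in place of methyl on an aromatic carbon. In other words, the 3,4-dimethylphenyl group of compound 3 becomes a 3-methylphenyl group, and nothing else about the molecule changes. The group that leaves is a single carbon with no ring, no donors and no acceptors, so the molecule becomes slightly smaller.

Among the compounds with values here, with no measured pair of this kind to lean on, the step is expected to be modest. Compound 4 is expected to give a number close to that of compound 3, leaning toward a somewhat weaker inhibition, with the step of a 1.8-fold higher number from compound 3 to compound 4 (0.26 log units; within the scatter) most likely lying near or just beyond the scatter. Compound 4 is therefore estimated at 500 nM, in a range from 150 nM to 2000 nM.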

Compound 4, half-maximal inhibitory concentration: 5730 nM
Compound 4: middle estimate off by 11-fold (1.06 log units), on the low side, outside the stated range (above it).
By their numbers in this assay, from the lowest: compound 3; then compounds 2 and 4 (each within the scatter of the next). At a limit, above all of these: compound 1.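

Within the data shown here, the earlier compounds differ from one another in more than one place, so this is the first pair in which a single change can be read on its own. In this assay, going from the 3,4-dimethylphenyl group to the 3-methylphenyl group gives a 21-fold higher number from compound 3 to compound 4 (1.32 log units; beyond the scatter), which shows that this position, on an aromatic carbon ortho to a methyl group and para to a large group, matters greatly in this pair: the loss of one methyl, a single carbon, is enough to weaken inhibition well beyond the scatter. Compound 4 still gives a measured number, and compound 1 remains the only compound at a limit, which is a limit and not a number: the limit of > 10000 nM in this assay, at which 1 of the 4 values shown sits.

Only methyl and hydrogen are shown at this position, so the data cannot tell whether the methyl itself is needed or whether another group, such as a chlorine atom, a methoxy group or an amine, would serve as well. The data do not explain so large a step. They also leave open whether the other methyl matters as much, a question that a 4-methylphenyl group would answer.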